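From chloromethyl to acetamidomethyl on the shared core

This account rests on a few compounds, and the source may have more. Where it says the series, first, only, none or still open, it means among the compounds named here.

Three compounds sharing one core, and differing at a single aromatic carbon, have been measured in a toxicity assay on CCRF-CEM cells (Homo sapiens) for cytotoxicity; a lower number here means that less compound is tolerated, a higher number that more compound is tolerated. Compound 1 `COc1cccc2c1nc(-c1c(F)cccc1F)n2Cc1c(F)cccc1F`, with methoxy, gives 44.3 uM. Compound 2 `O=Cc1cccc2c1nc(-c1c(F)cccc1F)n2Cc1c(F)cccc1F`, with formyl, gives 0.82 uM. Compound 3 `Fc1cccc(F)c1Cn1c(-c2c(F)cccc2F)nc2c(CCl)cccc21`, with chloromethyl, gives 13.4 uM, the second highest of the three numbers. It is reached by a 3.3-fold lower number from compound 1 to compound 3 (0.52 log units; beyond the scatter), a modest step, and by a 16-fold higher number from compound 2 to compound 3 (1.21 log units; beyond the scatter), a large one.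

Compound 4 `CC(=O)NCc1cccc2c1nc(-c1c(F)cccc1F)n2Cc1c(F)cccc1F` has acetamido in place of chloro on a saturated chain carbon bound to an aromatic carbon. Among the compounds with values here, no measured step makes this exchange, so the evidence is indirect. The largest swap seen, a 54-fold lower number from compound 1 to compound 2 (1.73 log units; beyond the scatter), involves formyl, which compound 4 does not carry. Compound 1 lies much closer to compound 3, as a 3.3-fold lower number from compound 1 to compound 3 (0.52 log units; beyond the scatter) shows, so a modest rise in this assay is expected rather than a large move. The expected change is a 2.1-fold higher number from compound 3 to compound 4 (0.32 log units; beyond the scatter). For compound 4 the estimated value is 28 uM, with an expected range of 9 uM to 85 uM.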

Compound 4, half-maximal toxic concentration: 20.8 uM
The estimate for compound 4 lay 1.3-fold (0.13 log units) above the measured number, within the range that was stated.
By their numbers in this assay, from the lowest: compound 2; then compounds 3 and 4 (each within the scatter of the next); then compound 1.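

In this assay, putting acetamido in place of chloro on a saturated chain carbon bound to an aromatic carbon leaves the number within the scatter (a 1.6-fold higher number from compound 3 to compound 4 (0.19 log units; within the scatter)), so this exchange of 1 heavy atom for 4, which adds a hydrogen-bond donor and acceptor, does not separate the two compounds here. Compound 4 sits far from the formyl compound (a 25-fold higher number from compound 2 to compound 4 (1.40 log units; beyond the scatter)) but only modestly from the methoxy compound (a 2.1-fold lower number from compound 1 to compound 4 (0.33 log units; beyond the scatter)), so among the four groups at this aromatic carbon, formyl alone stands apart by a large step. Nothing measured here accounts for these numbers.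

The compounds shown leave open whether a plain aminomethyl group or a longer chain carrying the amide would stay in this range. They also leave open whether a carboxylic acid or hydroxymethyl at this aromatic carbon would approach the low number seen with formyl.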